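Urea-to-benzotriazole carbonyl amide in a quinoline series

The compounds below may be only part of what the source reports. "The series", "measured", "known", "first", "only" and "open" are said of these compounds alone.

Measured compounds in a functional assay on MIA PaCa-2 cells (Homo sapiens), read by MTT assay, with a stated time of 72 h; on this read-out lower numbers stand for stronger inhibition and higher numbers for weaker inhibition:
compound 1 `COc1cc(NC(C)CCCNC(=O)NCC2CCCCC2)c2ncccc2c1` gives 60000 nM
compound 2 `COc1cc(NC(C)CCCNC(=O)NCc2ccncc2)c2ncccc2c1` gives 20000 nM
compound 3 `COc1cc(NC(C)CCCNC(=O)NCc2ccccc2)c2ncccc2c1` gives 21000 nM

Compound 1 stands at the highest number of the three, so it is the weakest inhibitor in this assay by the numbers shown. Its nearest neighbour is compound 3, with a 2.9-fold lower number from compound 1 to compound 3 (0.46 log units; beyond the scatter); its furthest is compound 2, with a 3.0-fold lower number from compound 1 to compound 2 (0.48 log units; beyond the scatter). Between compound 2 and compound 3 the step is a 1.1-fold higher number from compound 2 to compound 3 (0.02 log units; within the scatter), so the two aromatic ring variants sit together.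

Compound 4 `COc1cc(NC(C)CCCNC(=O)n2nnc3ccccc32)c2ncccc2c1` is not yet measured. Relative to compound 1 the change is a group of 9 heavy atoms (6 carbon, 3 nitrogen; one five-membered aromatic ring with 3 hetero atoms, one six-membered aromatic ring of carbon only) in place of a group of 8 heavy atoms (7 carbon, 1 nitrogen; one six-membered non-aromatic ring of carbon only), on a carbonyl carbon. This is a larger alteration than either measured step, since the whole (cyclohexylmethyl)amino group on the carbonyl carbon is replaced rather than the cyclohexyl alone. Within the data shown here, the two measured steps from compound 1 both ran to modestly lower numbers when a saturated ring gave way to an aromatic one, and compound 4 also brings aromatic rings in; a modest lowering is therefore expected, but with wide uncertainty because no measured step mirrors this change. For compound 4 the estimate in this assay is 25000 nM, range 8000 nM to 80000 nM, corresponding to an expected step of a 2.4-fold lower number from compound 1 to compound 4 (0.38 log units; beyond the scatter).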

Compound 4, half-maximal inhibitory concentration: 84000 nM
The estimate for compound 4 lay 3.4-fold (0.53 log units) below the measured number; measured number above the stated range.
By their numbers in this assay, from the lowest: compounds 2 and 3 (each within the scatter of the next); then compounds 1 and 4 (each within the scatter of the next).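

In this assay, aromatic rings on this carbonyl carbon do not by themselves go with the lower numbers of the ureas: for the benzotriazole carbonyl amide, the data show a 4.0-fold higher number from compound 3 to compound 4 (0.60 log units; beyond the scatter) and a 4.2-fold higher number from compound 2 to compound 4 (0.62 log units; beyond the scatter). Against the saturated urea, the same change gives a 1.4-fold higher number from compound 1 to compound 4 (0.15 log units; within the scatter), so compound 4 sits with compound 1 rather than with the two aromatic ureas. The gain seen with phenyl and pyridin-4-yl therefore does not carry over to this replacement, which also takes away the hydrogen-bond donor of the leaving group.

No measurement at hand accounts for this result. Open, from the compounds shown here alone, is whether the loss of that donor or the ring system itself matters more, which a benzyl urea with a methyl group on that nitrogen, or an indole on the same carbonyl carbon, could help to separate.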